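A few compounds are considered here, and "the series" means these few. Any claim that something is new, unique, unknown or untested is made for them only; others in the source may bear on it.

Measured so far in a functional assay on K562 cells (Homo sapiens) for inhibition, read by CCK-8 assay, with a stated time of 72 h; on this read-out lower numbers stand for stronger inhibition and higher numbers for weaker inhibition:
- compound 1 `O=C(/C=C/c1cccnc1)NCCCCCc1ccc(S(=O)(=O)Nc2ccccc2)cc1`: 146 nM
- compound 2 `O=C(/C=C/c1cccnc1)NCCCCCCCc1ccc(S(=O)(=O)Nc2ccccc2)cc1`: 56.5 nM
- compound 3 `Cc1ccc(C)c(NS(=O)(=O)c2cccc(CCCCCCNC(=O)/C=C/c3cccnc3)c2)c1`: 0.84 nM

Of these three numbers, the lowest belongs to compound 3 at 0.84 nM, and its gaps to compound 2 and compound 1 both lie beyond the scatter.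

The next compound is compound 4 `O=C(/C=C/c1cccnc1)NCCCCCCc1cccc(S(=O)(=O)Nc2ccc(F)c(Cl)c2)c1`, which differs from compound 3 as follows: 3-chloro-4-fluorophenyl in place of 2,5-dimethylphenyl on a sulfonamide nitrogen. In short, 3-chloro-4-fluorophenyl stands in place of 2,5-dimethylphenyl on a sulfonamide nitrogen.

For the measured compounds named here, no two measured compounds differ in one place only, so the series offers no direct step to carry over to this change. Compound 1 and compound 2 cannot isolate the contribution of this group. The expectation therefore rests mainly on the standing of compound 3: at 0.84 nM, it sits far below the other two, and a change of group from so low a number seems more likely to raise it than to lower it. The direction remains uncertain, and a result within the scatter would not be surprising.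

A modest loss is expected, with an estimated 3.0-fold higher number from compound 3 to compound 4 (0.47 log units; beyond the scatter). The estimate in this assay for compound 4 is 2.5 nM, with an expected range of 0.5 nM to 12 nM.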

Compound 4, half-maximal inhibitory concentration: 5.31 nM
The estimate for compound 4 lay 2.1-fold (0.33 log units) below the measured number, within the range that was stated.
By their numbers in this assay, from the lowest: compound 3; then compound 4; then compound 2; then compound 1.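

In this assay, for the compounds shown here, the change from 2,5-dimethylphenyl to 3-chloro-4-fluorophenyl on a sulfonamide nitrogen gives the first single-place reading: a 6.3-fold higher number from compound 3 to compound 4 (0.80 log units; beyond the scatter). This position therefore responds to the choice of aryl group even though the two groups match in heavy-atom count, in having one six-membered aromatic ring of carbon only, and in carrying no hydrogen-bond donors or acceptors, while compound 4 still holds a low value of 5.31 nM after the exchange. Nothing available accounts for the size or direction of this step.

Because the two methyl groups leave and the chlorine and fluorine enter in a single step, this pair cannot show whether the loss follows from what left, from what entered, or from both. From the compounds shown here alone, whether a 3-chlorophenyl, a 4-fluorophenyl, a 2-methylphenyl or a pyridyl ring on the same nitrogen would stay close to compound 3 or to compound 4 remains open, as does whether this step would keep its size on a different chain.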